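One added chloro on compound 2

This account rests on a few compounds, and the source may have more. Where it says the series, first, only, none or still open, it means among the compounds named here.

Compound 1 `O=[N+]([O-])c1cccc(-c2nn(-c3ccccc3)cc2C(Nc2nc3ccccc3s2)c2c(O)ccc3ccccc23)c1`: 43900 nM
Compound 2 `Oc1ccc2ccccc2c1C(Nc1nc2ccccc2s1)c1cn(-c2ccccc2)nc1-c1cccc(Cl)c1`: 20700 nM

Both numbers come from a functional assay on MCF7 cells (Homo sapiens) for antiproliferative activity, read by MTT assay, with a stated time of 48 h; on this read-out lower numbers stand for stronger inhibition and higher numbers for weaker inhibition. Of the two, compound 2 has the lower number, at 20700 nM, and is the stronger inhibitor in this assay. The next analogue is compound 3 `Oc1ccc2ccccc2c1C(Nc1nc2ccc(Cl)cc2s1)c1cn(-c2ccccc2)nc1-c1cccc(Cl)c1`. It differs from compound 2 by chloro in place of hydrogen on an aromatic carbon, so that 1,3-benzothiazol-2-yl becomes 6-chloro-1,3-benzothiazol-2-yl.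

Among the compounds with values here, only one measured step is available, and it bears on this change only indirectly. That step, a 2.1-fold lower number from compound 1 to compound 2 (0.33 log units; beyond the scatter), is modest and also brings in a chloro, but there it replaces nitro at another place in the molecule. Within the data shown here, no measured pair shows the effect of a chloro at the new place, so the direction remains uncertain. A similarly modest step towards a lower number is expected at most, and it may stay within the scatter. The expected change is a 1.5-fold lower number from compound 2 to compound 3 (0.17 log units; within the scatter). In this assay the estimate for compound 3 is 14000 nM, with an expected range of 5500 nM to 38000 nM.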

Compound 3, half-maximal inhibitory concentration: 17500 nM
Beside the measured number, compound 3's estimate is 1.3-fold (0.10 log units) below it; low and high end bracket the measured number.
By their numbers in this assay, from the lowest: compounds 3 and 2 (each within the scatter of the next); then compound 1.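

In this assay, within the data shown here, the first measurement at this position gives a 1.2-fold lower number from compound 2 to compound 3 (0.07 log units; within the scatter), so chloro in place of hydrogen on this aromatic carbon, para to a fused ring, leaves compound 2 and compound 3 indistinguishable in this read-out. Among these compounds, the earlier compounds could not show this: their only step, a 2.1-fold lower number from compound 1 to compound 2 (0.33 log units; beyond the scatter), lay beyond the scatter but concerned chloro in place of nitro at another place, whereas the present step shows that the change from 1,3-benzothiazol-2-yl to 6-chloro-1,3-benzothiazol-2-yl brings no shift that can be told from the scatter. Nothing given here accounts for this result.

As far as these compounds go, one chloro at one place cannot show whether this position is generally insensitive, and it remains open whether a methoxy group, an amine or a carboxylic acid there would move the number beyond the scatter. Also open, from the compounds shown here alone, is whether the same 6-chloro-1,3-benzothiazol-2-yl group would read the same way in a compound that keeps the nitro group of compound 1.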